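The source may hold more compounds than are shown below. What is called first, only, known or untested is meant among the compounds shown, and "the series" means these compounds.

Measured compounds in a functional assay on HepG2 cells (Homo sapiens) for antiproliferative activity, read by MTT assay, with a stated time of 24 h; a lower number here means a stronger inhibitor, a higher number a weaker inhibitor:
compound 1 `Clc1ccc(C2=NN(c3ccc(-c4ccccc4)nn3)C(c3ccc(Cl)cc3)C2)cc1`: 10000 nM
compound 2 `Fc1ccc(C2CC(c3ccc(Cl)cc3)=NN2c2ccc(-c3ccccc3)nn2)cc1`: 10000 nM
compound 3 `FC(F)(F)c1ccc(C2CC(c3ccc(Cl)cc3)=NN2c2ccc(-c3ccccc3)nn2)cc1`: 8330 nM

Compound 2 sits level with compound 1 at the digits shown, the two of them together the highest numbers of the three; its nearest neighbour is compound 1, with no change at the digits printed from compound 1 to compound 2 (within the scatter), and its furthest is compound 3, with a 1.2-fold lower number from compound 2 to compound 3 (0.08 log units; within the scatter). The remaining pair shows a 1.2-fold lower number from compound 1 to compound 3 (0.08 log units; within the scatter). All three steps fall within the scatter, so the series as measured is flat.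

Compound 4 `COc1ccc(C2=NN(c3ccc(-c4ccccc4)nn3)C(c3ccc(F)cc3)C2)cc1` differs from compound 2 by methoxy in place of chloro on an aromatic carbon. Among the compounds with values here, none of the measured steps exchanges a halogen for methoxy, and none touches this ring: the three steps swap chloro, fluoro and trifluoromethyl on the other aryl ring, and each left this assay unchanged within the scatter. Within the data shown here, no measured step therefore bears directly on the change to compound 4; the only guide is that every variation so far has left the number where it was. The expectation is accordingly a step of no change at the digits printed from compound 2 to compound 4 (within the scatter), none beyond the scatter. Compound 4 is estimated at 10000 nM, in the range 5000 nM to 20000 nM.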

Compound 4, half-maximal inhibitory concentration: 9160 nM
Estimate against measurement, compound 4: 1.1-fold (0.04 log units) above; low and high end bracket the measured number.
By their numbers in this assay, from the lowest: compounds 3, 4, 1 and 2 (each within the scatter of the next).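

In this assay, within the data shown here, the first exchange on the aryl ring that the earlier steps left untouched, 4-chlorophenyl to 4-methoxyphenyl, gives a 1.1-fold lower number from compound 2 to compound 4 (0.04 log units; within the scatter). This position therefore now has a reading of its own, and the number holds even though methoxy carries a hydrogen-bond acceptor and chloro carries none. Nothing available accounts for this result or connects it to a property of either group.

Going by these compounds, a single exchange says little about this position as a whole, and whether an amine or a carboxylic acid on this ring would give a step beyond the scatter remains open. Among these compounds, with every step so far within the scatter, it also remains open which part of the structure, if any, governs the number in this assay.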